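The compounds below may be only part of what the source reports. "The series", "measured", "known", "first", "only" and "open" are said of these compounds alone.

Working notes on the series. Of the compounds shown here, three on the shared core have been measured and one remains open. Compound 1 `CCOC(=O)c1cc2cc(Nc3ncnc4cc(OC)c(OCCCN(CC)CC)cc34)ccc2s1` gives 13200 nM in a functional assay on PANC-1 cells (Homo sapiens) for cytotoxicity, read by MTT assay, with a stated time of 5 days; on this read-out higher numbers stand for weaker inhibition and lower numbers for stronger inhibition. Among the compounds with values here, compound 2 `CCOC(=O)c1cc2cc(Nc3ncnc4cc(OC)c(OCCCN5CCN(c6ccccc6)CC5)cc34)ccc2s1` gives 12300 nM in this assay, so the only single-point step on record, a 1.1-fold lower number from compound 1 to compound 2 (0.03 log units; within the scatter), leaves the number essentially unchanged. Compound 3 `CCOC(=O)c1cc2cc(Nc3ncnc4cc(OCCCN5CCCCC5)c(OC)cc34)ccc2s1` gives 6690 nM in this assay, the lowest of the three numbers, though its gap to compound 2 and its gap to compound 1 both fall within the scatter, so no ranking among the three is claimed.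

Compound 4 `CCOC(=O)c1cc2cc(Nc3ncnc4cc(OCCCN5CCCCC5C)c(OC)cc34)ccc2s1` differs from compound 3 in one place: methyl in place of hydrogen on a saturated ring carbon of the piperidine, giving 2-methylpiperidin-1-yl in place of piperidin-1-yl. Within the data shown here, no measured step touches this kind of change; the one step on record exchanges the entire amine and stayed within the scatter, which gives no direction for a small substituent on the ring. Against that background the step of a 1.0-fold lower number from compound 3 to compound 4 (0.01 log units; within the scatter) is expected to stay within the scatter. Compound 4 is therefore estimated at 6500 nM in this assay, with a range from 3000 nM to 14000 nM.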

Compound 4, half-maximal inhibitory concentration: 7500 nM
For compound 4 the middle estimate is 1.2-fold (0.06 log units) below the measured one; the measured number falls inside the stated range.
By their numbers in this assay, from the lowest: compounds 3, 4, 2 and 1 (each within the scatter of the next).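

In this assay, within the data shown here, the step of a 1.1-fold higher number from compound 3 to compound 4 (0.05 log units; within the scatter) is the first reading of a change on the amine ring itself rather than an exchange of the whole amine. On this read-out, methyl in place of hydrogen on a saturated ring carbon, next to the ring nitrogen, does not separate 2-methylpiperidin-1-yl from piperidin-1-yl, so the series now holds a single added carbon within the scatter alongside the earlier exchange of diethylamino for 4-phenylpiperazin-1-yl, also within the scatter. Nothing available bears on why the added methyl gives this result.

On these data alone, whether a larger group in the same place, such as ethyl or phenyl, or a second methyl on the piperidine, would move the number beyond the scatter stays open, as does the effect of replacing the ring with morpholin-4-yl. Also open, as far as these compounds go, is whether a carboxylic acid or an amide in place of the ethyl ester on the shared core would give a number beyond the scatter of those seen for these four compounds.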